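Working notes on compounds 1 to 4: methyl to methylsulfanyl

A few compounds are considered here, and "the series" means these few. Any claim that something is new, unique, unknown or untested is made for them only; others in the source may bear on it.

Compound 1, `Cc1ncnc2c1c(I)cn2[C@@H]1O[C@H](CO)[C@@H](O)[C@H]1O`. In an ADME assay on BJ cells (Homo sapiens), read by MTT assay, with a stated time of 72 h (on this read-out higher numbers stand for weaker inhibition and lower numbers for stronger inhibition), compound 1 gives only a limit, > 100000 nM.
Compound 2, `CSc1ncnc2c1c(-c1ccccc1)cn2[C@@H]1O[C@H](CO)[C@@H](O)[C@H]1O`. In this assay compound 2 gives only a limit, > 100000 nM.
Compound 3, `Cc1ncnc2c1c(-c1cccs1)cn2[C@@H]1O[C@H](CO)[C@@H](O)[C@H]1O`. In this assay compound 3 gives only a limit, > 100000 nM.

Compound 3 stands on a limit, and the two other values shown for the series are limits as well, so no order among compounds 1, 2 and 3 can be read from these numbers. Going by the values given here, the only step between measured compounds that differ in one place is a step that the two limits leave unreadable from compound 1 to compound 3, which the two limits leave unreadable; this rests on (the limit of > 100000 nM in this assay, at which 3 of the 3 values shown sit).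

Compound 4 is `CSc1ncnc2c1c(-c1cccs1)cn2[C@@H]1O[C@H](CO)[C@@H](O)[C@H]1O`. Its difference from compound 3 is methylsulfanyl in place of methyl on an aromatic carbon. Compound 2 already carries methylsulfanyl at the same place on the shared core, and in this assay compound 2 shows only a limit. Among the compounds with values here, no measured step therefore bears on this change in a readable way; the sole relevant step, a step that the two limits leave unreadable from compound 1 to compound 3, has no readable size.

With every value shown sitting at the limit, compound 4 is expected to remain there too, and the step that the limit leaves unreadable from compound 3 to compound 4 is expected to be none beyond the scatter. The estimate for compound 4 in this assay is 150000 nM, with a range from 50000 nM to 500000 nM, most likely reported again as a limit.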

Compound 4, half-maximal inhibitory concentration: 96900 nM
Beside the measured number, compound 4's estimate is 1.5-fold (0.19 log units) above it; measured number inside the range.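

In this assay, going by these compounds alone, compound 4 is the first compound of the series to give a number rather than a limit, which turns the change at this place, on an aromatic carbon opposite the ring nitrogen, into a step with a floor. Methylsulfanyl in place of methyl gives an at least 1.0-fold lower number from compound 3 to compound 4 (0.01 log units; that floor lies within the scatter), so the data support no claim of a change beyond the scatter. With methylsulfanyl held constant, thiophen-2-yl in place of phenyl gives an at least 1.0-fold lower number from compound 2 to compound 4 (0.01 log units; that floor lies within the scatter), and the full size of both steps stays unknown because each starts from a compound that gives only a limit: the limit of > 100000 nM in this assay, at which 3 of the 4 values shown sit.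

Still open, on these data alone, is whether an amine or a longer chain such as ethylsulfanyl at this place would give a number clearly apart from that of compound 4. Also open is whether the methylsulfanyl and thiophen-2-yl groups each contribute to a readable number, since no pair shown compares either change between two exact values.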